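Furan-2-yl in Place of Pyridin-2-yl on the Arm

The source may hold more compounds than are shown below. What is called first, only, known or untested is meant among the compounds shown, and "the series" means these compounds.

Compound 1 `CN(Cc1ccc(B(O)O)cn1)c1ccc(C(=O)Nc2ccc(F)cc2)cn1` gives 1700 nM in a functional assay on RBL cells for antagonist activity at C-X-C chemokine receptor type 1 (Homo sapiens), read by fluorescence and calcium flux, with a stated time of 30 min; on this read-out higher numbers stand for weaker inhibition and lower numbers for stronger inhibition. Compound 2 `O=C(Nc1ccc(F)cc1)c1ccc(N(Cc2ccccn2)Cc2ccc(B(O)O)cn2)nc1` gives > 5000 nM. Compound 3 `O=C(O)CN(Cc1ccc(B(O)O)cn1)c1ncc(C(=O)Nc2ccc(F)cc2)cn1` gives > 5000 nM.

The values of compound 2 and compound 3 are limits of this assay, not numbers, so only compound 1 has a measured number. For the measured compounds named here, the single step between measured compounds is an at least 2.9-fold higher number from compound 1 to compound 2 (0.46 log units; beyond the scatter), which carries compound 2 past the limit; this is recorded as the limit of > 5000 nM in this assay, at which 2 of the 3 values shown sit. Compound 2 therefore stands at the weak end of what is known here, with no numeric value of its own.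

Compound 4 `O=C(Nc1ccc(F)cc1)c1ccc(N(Cc2ccc(B(O)O)cn2)Cc2ccco2)nc1` is not yet measured. It differs from compound 2 by furan-2-yl in place of pyridin-2-yl on a saturated chain carbon bound to a nitrogen on an aromatic ring. Going by the values given here, no measured step exchanges one aromatic group for another at this carbon; the only step touching this place, an at least 2.9-fold higher number from compound 1 to compound 2 (0.46 log units; beyond the scatter), shows that the arm bearing pyridin-2-yl already sits at the limit. Swapping it for furan-2-yl is expected to give no step beyond the scatter, with compound 4 estimated at 5000 nM, most likely between 2000 nM and 12000 nM. This expectation corresponds to a number no higher from compound 2 to compound 4 (the limit leaves the size open), and compound 4 is expected, more often than not, to be reported only as a limit again.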

Compound 4, half-maximal inhibitory concentration: 3.3 nM
For compound 4 the middle estimate is 1500-fold (3.18 log units) above the measured one; measured number below the stated range.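

In this assay, the outcome at this saturated chain carbon depends on which aromatic ring it carries: furan-2-yl in place of pyridin-2-yl gives an at least 1500-fold lower number from compound 2 to compound 4 (3.18 log units; beyond the scatter), so the loss seen earlier does not extend to every aromatic ring at this place. Against hydrogen, furan-2-yl gives a 520-fold lower number from compound 1 to compound 4 (2.71 log units; beyond the scatter), while pyridin-2-yl gave an at least 2.9-fold higher number from compound 1 to compound 2 (0.46 log units; beyond the scatter), so the same place carries steps in opposite directions. As far as these compounds go, the size of the step to furan-2-yl remains open, since compound 2 stands only at a limit of the assay: the limit of > 5000 nM in this assay, at which 2 of the 4 values shown sit.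

From the compounds shown here alone, whether a thiophen-2-yl or phenyl group at this carbon would behave like furan-2-yl or like pyridin-2-yl remains open. Equally open, going by these compounds, is what a longer chain carrying furan-2-yl would give.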